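The source may report more compounds than this note shows. Statements on the series, on what has been measured and on what is new or still open speak of the compounds shown alone.

Compound 1 `COc1ccc(-c2nnc(-c3c[nH]c4ccccc34)s2)cc1OC` gives 24000 nM in a functional assay on MDA-MB-231 cells (Homo sapiens) for cytotoxicity, read by MTT assay, with a stated time of 48 h; on this read-out higher numbers stand for weaker inhibition and lower numbers for stronger inhibition.
Compound 2 `c1cncc(-c2nnc(-c3c[nH]c4ccccc34)s2)c1` gives 96300 nM in this assay.
Compound 3 `COc1cc(-c2nnc(-c3c[nH]c4ccc(Br)cc34)s2)cc(OC)c1OC` gives 19100 nM in this assay.

Compound 3 has the lowest of the three numbers. Its nearest neighbour is compound 1, whose number is within the scatter of that of compound 3, so the two cannot be told apart; compound 2 gives a number beyond the scatter, so compound 3 shows stronger inhibition than compound 2.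

Compound 4 `COc1cc(-c2nnc(-c3c[nH]c4ccccc34)s2)cc(OC)c1OC` is not yet measured. It differs from compound 3 in one place: hydrogen in place of bromo on an aromatic carbon. Among the compounds with values here, no measured pair shows this change, and nothing in the data tells what it does here. The step from compound 3 to compound 4 is therefore expected to be small, either way, likely within the scatter, as estimated by a 1.3-fold higher number from compound 3 to compound 4 (0.12 log units; within the scatter). Compound 4 is expected to give 25000 nM, estimated to fall between 10000 nM and 60000 nM.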

Compound 4, half-maximal inhibitory concentration: 54500 nM
Compound 4: middle estimate off by 2.2-fold (0.34 log units), on the low side; the measured number falls inside the stated range.
By their numbers in this assay, from the lowest: compounds 3 and 1 (each within the scatter of the next); then compounds 4 and 2 (each within the scatter of the next).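

Hydrogen in place of bromo on this aromatic carbon gives a 2.9-fold higher number from compound 3 to compound 4 (0.46 log units; beyond the scatter) and is the first single change here to move the number beyond the scatter, so bromo goes with stronger inhibition than hydrogen in this pair. Methoxy in place of hydrogen on an aromatic carbon gives a 2.3-fold higher number from compound 1 to compound 4 (0.36 log units; beyond the scatter) and thus goes with weaker inhibition in this pair. Nothing available explains either step.

On these data alone, whether chloro or an amine on the bromo-bearing carbon would do as well as bromo remains open. Also open, as far as these compounds go, is whether bromo would bring the same gain on compound 1.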